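Chloro on the acrylamide warhead across two cores

The source may hold more compounds than are shown below. What is called first, only, known or untested is meant among the compounds shown, and "the series" means these compounds.

Measured compounds:
compound 1, `C=CC(=O)Nc1cc(Nc2nc3c(c(-c4cn(C)c5ccc(F)cc45)n2)CSCC3)c(OC)cc1N(C)CCN(C)C`, gives 4550 nM in a functional assay on A549 cells (Homo sapiens) for inhibition, read by MTT assay, with a stated time of 72 h; a higher number here means a weaker inhibitor, a lower number a stronger inhibitor.
compound 2, `C=C(Cl)C(=O)Nc1cc(Nc2nc3c(c(-c4cn(C)c5ccc(F)cc45)n2)CSCC3)c(OC)cc1N(C)CCN(C)C`, gives 864 nM in this assay.
compound 3, `C=CC(=O)Nc1cc(Nc2nc3c(c(-c4cn(C)c5ccccc45)n2)CS(=O)(=O)CC3)c(OC)cc1N(C)CCN(C)C`, gives 8690 nM in this assay.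

Compound 1 and compound 2 share a core and differ by one change, (chloro in place of hydrogen on a double-bonded chain carbon bound to a carbonyl carbon). That change produced a 5.3-fold lower number from compound 1 to compound 2 (0.72 log units; beyond the scatter).

Compound 3 carries a different core; the difference between the core of compound 3 and the core of compound 1 is not broken down here. In this assay compound 3 and compound 1 sit within the scatter of each other, while compound 3 and compound 2 lie further apart than the scatter.

Compound 4, `C=C(Cl)C(=O)Nc1cc(Nc2nc3c(c(-c4cn(C)c5ccccc45)n2)CS(=O)(=O)CC3)c(OC)cc1N(C)CCN(C)C`, is not yet measured. It differs from compound 3 by chloro in place of hydrogen on a double-bonded chain carbon bound to a carbonyl carbon, the same change seen from compound 1 to compound 2 at the same place. The expectation rests on that one measured step: the estimate for compound 4 in this assay is 1900 nM, between 700 nM and 5500 nM, which means an expected step of a 4.6-fold lower number from compound 3 to compound 4 (0.66 log units; beyond the scatter), read off a 5.3-fold lower number from compound 1 to compound 2 (0.72 log units; beyond the scatter) applied to compound 3. Among the compounds with values here, only one earlier instance of this change is known, and the range is widened to allow for that.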

Compound 4, half-maximal inhibitory concentration: 881 nM
The estimate for compound 4 lay 2.2-fold (0.33 log units) above the measured number; the range from low to high includes it.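

In this assay, chloro in place of hydrogen on a double-bonded chain carbon bound to a carbonyl carbon again lowers the number, giving a 9.9-fold lower number from compound 3 to compound 4 (0.99 log units; beyond the scatter). The size of the step does not separate the two cores: the same change on two cores in this assay, a 5.3-fold lower number (0.72 log units; beyond the scatter) from compound 1 to compound 2 and a 9.9-fold lower number (0.99 log units; beyond the scatter) from compound 3 to compound 4, 1.9-fold (0.27 log units) apart, within the scatter of two such steps. Within the data shown here, this shows the change carrying over between the core of compound 1 and the core of compound 3 in this one cell assay, but it rests on only two pairs and does not show that the step would hold on any other core or in any other kind of assay, nor does it say why the number falls.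

Still open is whether the step is particular to chloro, since bromo, methyl and trifluoromethyl at the same place lie outside the compounds shown. Also open, as far as these compounds go, is whether the step persists when the dimethylaminoethyl chain is replaced by another amine, such as morpholine or piperazine.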